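Working notes: bromo to chloro in the series

The source may hold more compounds than are shown below. What is called first, only, known or untested is meant among the compounds shown, and "the series" means these compounds.

Measured so far in a functional assay on the whole organism for inhibition, with Echinochloa esculenta as the target; on this read-out lower numbers stand for stronger inhibition and higher numbers for weaker inhibition
- compound 1 `Cc1cc(Cl)ccc1/N=c1\sc(=S)n2n1CCCC2` gives 2880 nM
- compound 2 `CC(C)Oc1cc(-n2c(=S)n3n(c2=S)CCCC3)c(F)cc1Cl` gives 12.3 nM
- compound 3 `S=c1s/c(=N\c2ccc(Br)cc2)n2n1CCCC2` gives 245 nM

In this assay compound 3 gives 245 nM and stands second highest of the three numbers, with compound 1 higher and compound 2 lower, both gaps beyond the scatter. The step to compound 4 `S=c1s/c(=N\c2ccc(Cl)cc2)n2n1CCCC2` is chloro in place of bromo on an aromatic carbon, para to a large group, with chloro in place of bromo on an aromatic carbon as the whole of the change. Going by the values given here, compound 1 also carries chloro and gives 2880 nM, but it differs from compound 3 in a further place, so no measured pair isolates this exchange. No step beyond the scatter is expected, and only a slight rise in the number is allowed for. The expected step is a 1.2-fold higher number from compound 3 to compound 4 (0.09 log units; within the scatter), which lies within the scatter. For compound 4 the estimated value is 300 nM, with an expected range of 110 nM to 800 nM.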

Compound 4, half-maximal inhibitory concentration: 407 nM
The estimate for compound 4 lay 1.4-fold (0.13 log units) below the measured number, within the range that was stated.
By their numbers in this assay, from the lowest: compound 2; then compounds 3 and 4 (each within the scatter of the next); then compound 1.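

In this assay, chloro in place of bromo at this position, para to a large group, gives a 1.7-fold higher number from compound 3 to compound 4 (0.22 log units; within the scatter), so the two halogens are not separated on this read-out. With chloro held constant, the other new pair isolates hydrogen in place of methyl on an aromatic carbon and gives a 7.1-fold lower number from compound 1 to compound 4 (0.85 log units; beyond the scatter), so that exchange, unlike the halogen exchange, produces a step beyond the scatter in this single pair. Nothing available explains the size of either step.

Going by these compounds, whether this position tolerates groups other than the two halogens remains open, since a fluoro, methoxy, nitrile or amine group here would test more than a single close exchange. Going by these compounds alone, also open is whether the methyl step recurs with bromo in place of chloro, as only one pair defines it.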